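Cinnamamide series: para substituent on the styryl ring

The source may report more compounds than this note shows. Statements on the series, on what has been measured and on what is new or still open speak of the compounds shown alone.

Measured so far:
compound 1 `O=C(/C=C/c1ccccc1)Nc1ccc2ncnc(Nc3cccc(Br)c3)c2c1`, 3.96 ug/mL in a functional assay on A549 cells (Homo sapiens) for antiproliferative activity, read by MTT assay, with a stated time of 48 h; on this read-out higher numbers stand for weaker inhibition and lower numbers for stronger inhibition
compound 2 `COc1ccc(/C=C/C(=O)Nc2ccc3ncnc(Nc4cccc(Br)c4)c3c2)cc1`, 3.36 ug/mL
compound 3 `Cc1ccc(/C=C/C(=O)Nc2ccc3ncnc(Nc4cccc(Br)c4)c3c2)cc1`, 3.01 ug/mL

Compound 3 stands at the lowest of the three numbers, yet each of its steps to the others lies within the scatter: a 1.3-fold lower number from compound 1 to compound 3 (0.12 log units; within the scatter) and a 1.1-fold lower number from compound 2 to compound 3 (0.05 log units; within the scatter), as does a 1.2-fold lower number from compound 1 to compound 2 (0.07 log units; within the scatter).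

Compound 4 `O=C(/C=C/c1ccc([N+](=O)[O-])cc1)Nc1ccc2ncnc(Nc3cccc(Br)c3)c2c1` differs from compound 3 by nitro in place of methyl on an aromatic carbon. Among the measured compounds shown here, no measured step carries a nitro group; the steps measured here involved methyl and methoxy only, and all stayed within the scatter. On that evidence the change to compound 4 is expected to bring no shift beyond the scatter in this assay, giving a 1.1-fold higher number from compound 3 to compound 4 (0.04 log units; within the scatter) as the estimated step.

Compound 4 is estimated at 3.3 ug/mL, with a range from 1.5 ug/mL to 7.5 ug/mL.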

Compound 4, half-maximal inhibitory concentration: 1.85 ug/mL
Beside the measured number, compound 4's estimate is 1.8-fold (0.25 log units) above it; low and high end bracket the measured number.
By their numbers in this assay, from the lowest: compounds 4, 3, 2 and 1 (each within the scatter of the next, the first and the last beyond it).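

In this assay, among the compounds shown here, this position now yields its only step beyond the scatter, and a modest one, with nitro in place of hydrogen: a 2.1-fold lower number from compound 1 to compound 4 (0.33 log units; beyond the scatter). Against the substituted compounds nitro does not separate, with a 1.6-fold lower number from compound 3 to compound 4 (0.21 log units; within the scatter) and a 1.8-fold lower number from compound 2 to compound 4 (0.26 log units; within the scatter), so only the unsubstituted compound 1 stands apart from compound 4. No measurement at hand accounts for this step.

On these data alone, whether an amine or a carboxylic acid at this position would behave like nitro, like methyl or like hydrogen remains open. So does whether a chloro or nitrile group would also separate from compound 1.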